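From 4-Fluorophenyl to 3-Ethylphenyl on a Sulfonamide Nitrogen

A few compounds are considered here, and "the series" means these few. Any claim that something is new, unique, unknown or untested is made for them only; others in the source may bear on it.

Within the data shown here, in a functional assay on MCF7 cells (Homo sapiens) for antiproliferative activity, read by sulforhodamine B assay, with a stated time of 48 h (a higher number here means a weaker inhibitor, a lower number a stronger inhibitor), compound 2 (`O=C1NCCN1c1ccc(S(=O)(=O)Nc2ccc(F)cc2)cc1`) gives 690 nM as the only actual number in this small set. Compound 1 (`O=C1NCCN1c1ccc(S(=O)(=O)Nc2ccc(C3CCCCC3)cc2)cc1`) stands at > 1000 nM which is a limit of the assay and not a number. Compound 3 (`CC(C)(C)c1ccc(NS(=O)(=O)c2ccc(N3CCNC3=O)cc2)cc1`) stands at > 1000 nM which is likewise a limit.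

The unmeasured compound 4 (`CCc1cccc(NS(=O)(=O)c2ccc(N3CCNC3=O)cc2)c1`) keeps the shared core and carries 3-ethylphenyl in place of 4-fluorophenyl on a sulfonamide nitrogen is the counted change.

Among the measured compounds shown here, no measured step makes this same exchange. The nearest guide is the swap of fluoro for tert-butyl, which gives an at least 1.4-fold higher number from compound 2 to compound 3 (0.16 log units; that floor lies within the scatter) and so shows only a floor. The swap of cyclohexyl for fluoro gives an at least 1.4-fold lower number from compound 1 to compound 2 (0.16 log units; that floor lies within the scatter) and points the same way from the other side, again as a floor only. Together they suggest that an alkyl group in place of fluoro does not lower the number, though neither size can be read.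

A modest rise in this assay is therefore expected, close to the scatter, and a result reported only as a limit would be no surprise. The estimate is a 1.4-fold higher number from compound 2 to compound 4 (0.14 log units; within the scatter) as the expected step. For compound 4 the estimated value is 950 nM in a range from 350 nM to 2600 nM by this expectation.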

Compound 4, half-maximal inhibitory concentration: 130 nM
Compound 4: the middle estimate sits 7.3-fold (0.86 log units) above what was measured; the whole stated range lies above it.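

In this assay, placing 3-ethylphenyl where 4-fluorophenyl stood on a sulfonamide nitrogen gives a 5.3-fold lower number from compound 2 to compound 4 (0.72 log units; beyond the scatter), so this position can carry an alkyl-bearing phenyl group and still give a lower number. Among these compounds, the earlier steps from fluoro to an alkyl group showed only floors within the scatter, whereas this is the first step in the set with a readable size, and compound 4 goes against any reading that an alkyl group on this phenyl ring raises the number. Compound 1 and compound 3 remain at a limit of the assay and not at a number, so the step between them cannot be read and the set gives no order among the larger alkyl groups: the limit of > 1000 nM in this assay, at which 2 of the 4 values shown sit.

The compounds shown leave open whether the lower number follows from the ethyl group itself, from where it sits on the ring, or from the departure of the fluoro group, as all of these change together in this one step. They also leave open how a longer chain, an amine or a carboxylic acid on this phenyl ring would read in this assay.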